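From 2-chlorophenyl to 4-bromophenyl: an expected step

This account rests on a few compounds, and the source may have more. Where it says the series, first, only, none or still open, it means among the compounds named here.

Measured in a functional assay on HepG2 cells (Homo sapiens) for inhibition, read by MTT assay; a higher number here means a weaker inhibitor, a lower number a stronger inhibitor:
compound 1 `CCc1ccc(C(=O)Nc2ccc(Nc3ncnc4cc(OC)c(OC)cc34)cc2)cc1`: 72000 nM
compound 2 `COc1cc2ncnc(Nc3ccc(NC(=O)c4ccccc4F)cc3)c2cc1OC`: 13000 nM
compound 3 `COc1cc2ncnc(Nc3ccc(NC(=O)c4ccccc4Cl)cc3)c2cc1OC`: 26000 nM

Compound 3, at 26000 nM, sits level with compound 2, showing a 2.0-fold higher number from compound 2 to compound 3 (0.30 log units; within the scatter). Compound 1 lies clearly higher, and the change shows a 2.8-fold lower number from compound 1 to compound 3 (0.44 log units; beyond the scatter).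

Compound 4 `COc1cc2ncnc(Nc3ccc(NC(=O)c4ccc(Br)cc4)cc3)c2cc1OC` has 4-bromophenyl in place of 2-chlorophenyl on a carbonyl carbon. Among the compounds with values here, no measured step makes this exact change. The nearest guide is compound 1, whose 4-ethylphenyl carries the same number in its name, and leaving it gave a 5.5-fold lower number from compound 1 to compound 2 (0.74 log units; beyond the scatter). A step toward a higher number in this assay is therefore expected, though it may stay within the scatter. The expected step is a 1.5-fold higher number from compound 3 to compound 4 (0.19 log units; within the scatter). The estimate for compound 4 is 40000 nM, with a range from 14000 nM to 110000 nM.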

Compound 4, half-maximal inhibitory concentration: 35000 nM
For compound 4 the middle estimate is 1.1-fold (0.06 log units) above the measured one; the measured number falls inside the stated range.
By their numbers in this assay, from the lowest: compounds 2, 3 and 4 (each within the scatter of the next, the first and the last beyond it); then compound 1.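

The step of a 1.3-fold higher number from compound 3 to compound 4 (0.13 log units; within the scatter) leaves the two compounds level, so 4-bromophenyl and 2-chlorophenyl on this carbonyl carbon read alike here, although both the halogen and its place on the ring differ. Compound 4 still stands apart from the other two, with a 2.7-fold higher number from compound 2 to compound 4 (0.43 log units; beyond the scatter) and with a 2.1-fold lower number from compound 1 to compound 4 (0.31 log units; beyond the scatter) in the opposite direction. Nothing available explains these differences.

From the compounds shown here alone, what remains open is how far the halogen's place and its identity each count. A 4-chlorophenyl or an aminophenyl group on this carbonyl carbon could begin to separate them.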